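The source may report more compounds than this note shows. Statements on the series, on what has been measured and on what is new or still open speak of the compounds shown alone.

Measured in a functional assay on MCF7 cells (Homo sapiens) for inhibition, read by MTT assay, with a stated time of 72 h; on this read-out higher numbers stand for weaker inhibition and lower numbers for stronger inhibition:

- compound 1 `CN1CCN(c2cc(C(F)(F)F)nc(SCc3ccc(C(F)(F)F)cc3)n2)CC1`: 30200 nM
- compound 2 `Cc1csc(Sc2cc(C(F)(F)F)nc(SCc3ccc(C(F)(F)F)cc3)n2)n1`: 14500 nM

Of these two compounds, compound 2 has the lower number, 14500 nM, and so the stronger inhibition, though both values are high. The next compound, compound 3 `FC(F)(F)c1ccc(CSc2nc(Sc3ccccn3)cc(C(F)(F)F)n2)cc1`, keeps the shared core and alters one group, with pyridin-2-yl in place of 4-methyl-1,3-thiazol-2-yl on a sulfur.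

For the measured compounds named here, only one measured step bears on this change: a 2.1-fold lower number from compound 1 to compound 2 (0.32 log units; beyond the scatter). It is modest, and it exchanged a whole group on an aromatic carbon, bringing in the (4-methyl-1,3-thiazol-2-yl)sulfanyl group. The new change is narrower, as the sulfur stays and only the aromatic ring on it is replaced. Going by the values given here, no measured pair compares two such rings, so the data offer no direction for this swap. In this assay, the expected result is a 1.0-fold higher number from compound 2 to compound 3 (0.01 log units; within the scatter), which would be no shift beyond the scatter. The estimated value for compound 3 is 15000 nM, with an expected range from 6500 nM to 35000 nM.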

Compound 3, half-maximal inhibitory concentration: 43200 nM
For compound 3 the middle estimate is 2.9-fold (0.46 log units) below the measured one; the whole stated range lies below it.
By their numbers in this assay, from the lowest: compound 2; then compounds 1 and 3 (each within the scatter of the next).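

In this assay the ring carried on this sulfur clearly matters: pyridin-2-yl in place of 4-methyl-1,3-thiazol-2-yl gives a 3.0-fold higher number from compound 2 to compound 3 (0.47 log units; beyond the scatter) and so weakens inhibition, even though the two rings have the same count of heavy atoms. The sulfur link alone therefore does not secure the stronger inhibition of compound 2, for (pyridin-2-yl)sulfanyl in place of 4-methylpiperazin-1-yl gives a 1.4-fold higher number from compound 1 to compound 3 (0.16 log units; within the scatter) and so brings no real change. For now this position favours 4-methyl-1,3-thiazol-2-yl among the sulfur-linked rings shown, but no available evidence explains why the ring swap shifts the number.

On these data alone, the two rings differ in several ways at once, so it remains open whether the step comes from the methyl group or from the ring itself, and a plain 1,3-thiazol-2-yl on the same sulfur would separate the two. Also open, as far as these compounds go, is how a phenyl ring on that sulfur would read against compound 2 at 14500 nM as a reference, itself still a high number.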